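The compounds below may be only part of what the source reports. "The series", "measured", "known", "first", "only" and "open" are said of these compounds alone.

Compound 3 `O[C@H]1Cc2ccccc2C1NC1CCN(CCCc2c[nH]c3ccc(-n4cnnc4)cc23)CC1` sits at the weak end of this small set. In an assay on CHO cells for displacement of a labelled ligand from 5-hydroxytryptamine receptor 1B (Homo sapiens) (on this read-out lower numbers stand for stronger inhibition and higher numbers for weaker inhibition), compound 3 gives 300 nM, the highest of the three numbers. Compound 1 `O=S(=O)(NCC1CCN(CCCc2c[nH]c3ccc(-n4cnnc4)cc23)CC1)c1ccccc1` gives 60 nM in this assay, and compound 2 `CN(CC1CCN(CCCc2c[nH]c3ccc(-n4cnnc4)cc23)CC1)C(=O)Nc1ccccc1` gives 6.2 nM. The step of a 5.0-fold higher number from compound 1 to compound 3 (0.70 log units; beyond the scatter) swapped the group on the piperidine ring carbon, while the step of a 9.7-fold lower number from compound 1 to compound 2 (0.99 log units; beyond the scatter) changed the group at the end of the side chain instead.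

Compound 4 `CC(C)=CCCN(C)C1CCN(CCCc2c[nH]c3ccc(-n4cnnc4)cc23)CC1` carries the change (methyl(4-methylpent-3-en-1-yl)amino in place of (2-hydroxy-2,3-dihydro-1H-inden-1-yl)amino on a saturated ring carbon). Among the compounds with values here, only the step from compound 1 to compound 3 touches the same place, and it was of modest size; the step from compound 1 to compound 2 concerns another part of the molecule and says little about this one. Within the data shown here, there is no measured pair in which an open-chain group of this kind replaces a ring-bearing one, so the forecast rests on the observation that the one exchange on this ring carbon, a 5.0-fold higher number from compound 1 to compound 3 (0.70 log units; beyond the scatter), was of modest size rather than a large one.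

The expectation is a modest lowering, a 3.8-fold lower number from compound 3 to compound 4 (0.57 log units; beyond the scatter), on the grounds that compound 3 gives 300 nM and already stands at the high end. Compound 4 is therefore estimated at 80 nM in this assay, within a range from 20 nM to 320 nM.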

Compound 4, half-maximal inhibitory concentration: 24 nM
Estimate against measurement, compound 4: 3.3-fold (0.52 log units) above, and the stated range covers the measured number.
By their numbers in this assay, from the lowest: compound 2; then compound 4; then compound 1; then compound 3.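

At this saturated ring carbon, the earlier exchange was only of modest size, but a 13-fold lower number from compound 3 to compound 4 (1.10 log units; beyond the scatter) shows that a single exchange here can shift the number by a large step in this assay. The methyl(4-methylpent-3-en-1-yl)amino group has no ring, yet a 2.5-fold lower number from compound 1 to compound 4 (0.40 log units; beyond the scatter) also places it below the ((phenylsulfonyl)amino)methyl group, so a ring in this group is not required for a fairly low number; compound 2 goes against any simple rule that ring-free groups do best, since it keeps a phenyl ring and gives 6.2 nM, while compound 4 gives 24 nM. Nothing available explains why the number falls with this exchange.

Going by these compounds, the exchange from compound 3 to compound 4 removes the hydroxyl group and both rings and adds a double bond all at once, so the share of each change in the step remains unknown. A saturated 4-methylpentyl chain on the same nitrogen would test the double bond, and a plain benzyl group on that nitrogen would test whether a single aromatic ring is tolerated without the hydroxyl group.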